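A few compounds are considered here, and "the series" means these few. Any claim that something is new, unique, unknown or untested is made for them only; others in the source may bear on it.

Measured so far:
Compound 1 `CC(=O)c1ccc(OCCCCC#N)cc1O`: 0%
Compound 2 `CCCc1cc(C(C)=O)c(O)cc1OCCCCC#N`: 37%
Compound 3 `C=CCc1cc(C(C)=O)c(O)cc1OCCCCC#N`: 57%

In an assay on isolated protein for binding affinity to leukotriene B4 receptor 1 (Homo sapiens), tested at 1 uM (on this read-out lower numbers stand for less inhibition and higher numbers for more inhibition at the one concentration tested (going by the name of the read-out)), compound 3 stands highest of the three numbers. Its nearest neighbour is compound 2, and the step of a number 20 percentage points higher from compound 2 to compound 3 (beyond the scatter) lies beyond the scatter; the step of a number 57 percentage points higher from compound 1 to compound 3 (beyond the scatter) from the unsubstituted parent is larger still. Both measured steps that lead to compound 3, together with a number 37 percentage points higher from compound 1 to compound 2 (beyond the scatter), change only the group on the aromatic carbon, while the chain on the aromatic oxygen stays the same in all three compounds.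

Compound 4 `C=CCc1cc(C(C)=O)c(O)cc1OCCCCCC(C)=O` is not yet measured. It differs from compound 3 in exactly one place: 2-oxopropyl in place of cyano on a saturated chain carbon, four bonds along the chain from an oxygen on an aromatic ring. Going by the values given here, no measured step touches this end of the chain, so none of the three steps bears directly on the change; they show only that the allyl group, which compound 4 keeps, is compatible with the highest number seen. With no guidance from the data on the chain end, the step of a number 7 percentage points lower from compound 3 to compound 4 (within the scatter) is expected to be small, probably within the scatter, in either direction. Compound 4 is therefore estimated to give 50% in this assay, with a range from 25% to 75%.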

Compound 4, a percentage reported as inhibition, at one concentration (the size of the read-out at that concentration, not a potency): 58%
Estimate against measurement, compound 4: 8 percentage points below; low and high end bracket the measured number.
By their numbers in this assay, from the lowest: compound 1; then compound 2; then compounds 3 and 4 (each within the scatter of the next).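

In this assay, going by these compounds alone, the far end of the chain on the aromatic oxygen changes for the first time, and a number 1 percentage points higher from compound 3 to compound 4 (within the scatter) shows that, with the allyl group kept, the cyano group is not needed at this place to retain the number: 2-oxopropyl serves as well in this pair. The exchange is not a minimal one, since 4 heavy atoms replace 2 and a double bond outside the aromatic rings replaces a triple bond, while the count of 1 hydrogen-bond acceptor and 0 hydrogen-bond donors stays the same; the read-out does not separate the two compounds despite those differences. No measurement shown here explains why the two chain ends read alike.

Going by these compounds, it remains open whether the same exchange would leave the number unchanged with the propyl group of compound 2 or the hydrogen of compound 1 on the aromatic carbon, as it can be read only with allyl there. Also open, on these data alone, is how a carboxylic acid, an amine or a longer chain would read at this place, and whether compound 3 and compound 4 would still match in a full concentration series.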